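This account rests on a few compounds, and the source may have more. Where it says the series, first, only, none or still open, it means among the compounds named here.

Values in an ADME assay on the whole organism (Rattus norvegicus) for pharmacokinetics, at a dose of 1 mg/kg by the intravenous route; a lower number here means less compound in the circulation, a higher number more compound in the circulation at the dose given:
- compound 1 `O=C(c1cnco1)N1CCC(C(=O)N2N=CC[C@H]2c2ccccc2)CC1` gives 400 ng.h/mL
- compound 2 `Cc1nnc(N2CCC(C(=O)N3N=CC[C@H]3c3ccccc3)CC2)o1` gives 800 ng.h/mL

Among the measured compounds shown here, compound 2 stands within the scatter of compound 1, the only other measured compound. Compound 3 `Cc1nnc(N2CCC(C(=O)N3N=CC[C@H]3c3cc(F)cc(F)c3)CC2)o1` differs from compound 2 as follows: 3,5-difluorophenyl in place of phenyl on a saturated ring carbon. For the measured compounds named here, the only measured step is a 2.0-fold higher number from compound 1 to compound 2 (0.30 log units; within the scatter). Going by the values given here, it lies on an amine nitrogen in a ring, so it bears only loosely on a change on a saturated ring carbon, and no measured step covers this place. No step beyond the scatter is therefore expected in this assay. The expected step is a 1.1-fold higher number from compound 2 to compound 3 (0.05 log units; within the scatter). The estimate for compound 3 is 900 ng.h/mL, with an expected range of 400 ng.h/mL to 2000 ng.h/mL.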

Compound 3, area under the concentration-time curve: 1300 ng.h/mL
Estimate against measurement, compound 3: 1.4-fold (0.16 log units) below; measured number inside the range.
By their numbers in this assay, from the lowest: compounds 1, 2 and 3 (each within the scatter of the next, the first and the last beyond it).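

In this assay, the first step read on a saturated ring carbon, 3,5-difluorophenyl in place of phenyl, gives a 1.6-fold higher number from compound 2 to compound 3 (0.21 log units; within the scatter); this place therefore carries the two added fluorine atoms without a step beyond the scatter. No available evidence accounts for this step.

On these data alone, whether a methoxy group, an amine or a pyridine ring at this place would also stay within the scatter remains open. Also open, as far as these compounds go, is whether 3,5-difluorophenyl behaves the same way alongside the (1,3-oxazol-5-yl)carbonyl group of compound 1.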